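Swapping amino for methyl on the core of compound 1

The compounds below may be only part of what the source reports. "The series", "measured", "known", "first", "only" and "open" are said of these compounds alone.

Compound 1 `C#CCOc1ccc(-c2cc(-c3ccccc3OCC#C)nc(N)n2)cc1` was tested in an assay on BTI-TN-5B1-4 cells for inhibition of Amine oxidase [flavin-containing] B (Homo sapiens), read by fluorescence and Amplex Red, using microsomes, with a stated time of 30 min (on this read-out higher numbers stand for weaker inhibition and lower numbers for stronger inhibition), where compound 1 gives 22100 nM. Among the three compounds measured, this is the second highest number. Compound 2 `C#CCOc1ccc(-c2cc(-c3ccc(OCC#C)c(OCC)c3)nc(-c3ccccc3)n2)cc1` gives 29000 nM in this assay, and compound 3 `C#CCOc1ccc(-c2cc(-c3ccc(OCC#C)c(OCC)c3)nc(N)n2)cc1` gives 14000 nM; both lie within the scatter of compound 1, so no order can be read among the three. Among the compounds with values here, the only step measured within this set is a 2.1-fold lower number from compound 2 to compound 3 (0.32 log units; beyond the scatter). Compound 4 `C#CCOc1ccc(-c2cc(-c3ccccc3OCC#C)nc(C)n2)cc1` differs from compound 1 by methyl in place of amino on an aromatic carbon. Within the data shown here, no measured pair carries a methyl at this aromatic carbon, so the step from compound 2 to compound 3 shows only that exchanging the group there moves the number modestly. Compound 4 is therefore expected to land close to compound 1, with a small shift toward a higher number judged possible. The step expected from this change is a 1.4-fold higher number from compound 1 to compound 4 (0.13 log units; within the scatter). For compound 4 the estimate in this assay is 30000 nM, with a range from 12000 nM to 80000 nM.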

Compound 4, half-maximal inhibitory concentration: 18100 nM
Beside the measured number, compound 4's estimate is 1.7-fold (0.22 log units) above it; the measured number falls inside the stated range.
By their numbers in this assay, from the lowest: compounds 3, 4, 1 and 2 (each within the scatter of the next, the first and the last beyond it).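

In this assay, the exchange of amino for methyl gives a 1.2-fold lower number from compound 1 to compound 4 (0.09 log units; within the scatter) on the shared core, so at this aromatic carbon between two ring nitrogen atoms the two groups cannot be told apart by their numbers. Methyl has neither the hydrogen-bond donor nor the hydrogen-bond acceptor counted for amino, yet this pair shows no readable difference between them, something the earlier step, which exchanged phenyl for amino, could not show. Nothing available bears on why this result arises.

Going by these compounds, whether an ethyl, a methoxy or a carboxylic acid at this carbon would move the number beyond the scatter remains open. So does whether methyl in place of amino would read the same way on the core of compound 3, which carries an ethoxy group.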